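Swapping Furan for Thiophene on a Fused Lactone Core

A few compounds are considered here, and "the series" means these few. Any claim that something is new, unique, unknown or untested is made for them only; others in the source may bear on it.

Compound 1 `CC1(C)CC(=O)C2=C(C1)OC(=O)C(NC(=O)c1ccccc1)C2c1cccs1` and compound 2 `O=C1CCCC2=C1C(c1ccco1)C(NC(=O)c1ccccc1)C(=O)O2` share a fused core. In a functional assay on SW 1116 cells (Homo sapiens) for cytotoxicity, read by MTT assay, with a stated time of 24 h, tested at 1 ug/mL (a higher number here means a weaker effect of the compound at the concentration tested, a lower number a stronger effect), compound 1 gives 104%, and compound 2 gives 97.9%; compound 2 holds the lower of the two numbers, but the gap to compound 1 lies within the scatter, so neither stands apart. Compound 3 `O=C1CCCC2=C1C(c1cccs1)C(NC(=O)c1ccccc1)C(=O)O2` differs from compound 2 by thiophen-2-yl in place of furan-2-yl on a saturated ring carbon. Going by the values given here, with no measured pair showing this change, the step of a number 2.1 percentage points higher from compound 2 to compound 3 (within the scatter) is expected to be none beyond the scatter in this assay. Compound 3 is therefore estimated at 100%, within 88% to 112%.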

Compound 3, a percentage reported as activity, at one concentration (the size of the read-out at that concentration, not a potency): 81.7%
The estimate for compound 3 lay 18.3 percentage points above the measured number; the whole stated range lies above it.
By their numbers in this assay, from the lowest: compound 3; then compounds 2 and 1 (each within the scatter of the next).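

In this assay the saturated ring carbon proves sensitive to which ring it carries: thiophen-2-yl in place of furan-2-yl gives a number 16.2 percentage points lower from compound 2 to compound 3 (beyond the scatter) even though the two groups match in heavy atoms and differ only in sulfur for oxygen. Compounds 1 and 2 differ in more than one place, so they could not isolate this change. Nothing measured here explains the step. On these data alone, whether a phenyl or a pyridin-3-yl group on this carbon would lower the number further stays open, as does whether the step holds on other cores.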